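The source may hold more compounds than are shown below. What is called first, only, known or untested is meant among the compounds shown, and "the series" means these compounds.

Working notes on the triazole-linked series in a functional assay on SMMC-7721 cells (Homo sapiens) for cytotoxicity, read by MTT assay, with a stated time of 4 days; a higher number here means a weaker inhibitor, a lower number a stronger inhibitor.

The shared core carries a triazole bearing an aryl group; compound 1 `Cc1c(O)ccc2c1[C@H](Cn1cc(-c3ccc(Cl)cc3)nn1)[C@@]13CC(=O)[C@@](C)(CC[C@@H]21)C3` has 4-chlorophenyl there, and compound 2 `Cc1c(O)ccc2c1[C@H](Cn1cc(-c3ccccn3)nn1)[C@@]13CC(=O)[C@@](C)(CC[C@@H]21)C3` has pyridin-2-yl. In this assay compound 1 reaches only the limit of the method and gives > 20000 nM. In this assay compound 2 likewise reaches only the limit and gives > 20000 nM. The step that the two limits leave unreadable from compound 1 to compound 2 therefore cannot be read in size or direction, because the limit of > 20000 nM in this assay, at which 2 of the 2 values shown sit, holds for every value recorded so far: compound 2 stands at that limit, and nothing in the data separates it from compound 1.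

Compound 3 `Cc1c(O)ccc2c1[C@H](Cn1cc(-c3ccc(C(F)(F)F)cc3)nn1)[C@@]13CC(=O)[C@@](C)(CC[C@@H]21)C3` is not yet measured. Its difference from compound 2 is 4-(trifluoromethyl)phenyl in place of pyridin-2-yl on an aromatic carbon. Among the measured compounds shown here, the only measured step at this position, from 4-chlorophenyl to pyridin-2-yl, is unreadable, so no size or direction can be carried over to the change to 4-(trifluoromethyl)phenyl. The step that the estimate below means, a step that the limit leaves unreadable from compound 2 to compound 3, is expected to be none beyond the scatter. In this assay compound 3 is expected to give 30000 nM, within a range from 10000 nM to 100000 nM, most probably again only as a limit.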

Compound 3, half-maximal inhibitory concentration: > 20000 nM
Compound 3 ended at the assay's limit; the forecaster's own chance of this, stated with the estimate: 85%; the middle value lies beyond the limit too.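

The steps from compound 1 to compound 3 and from compound 2 to compound 3 cannot be read in size or direction, because compound 3 gives only a limit, as compound 1 and compound 2 do: the limit of > 20000 nM in this assay, at which 3 of the 3 values shown sit.

The compounds shown leave open whether any group at this position on the triazole gives a measurable value in this assay.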